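From 3-fluorophenyl to 4-cyanophenyl on the amide nitrogen

The source may hold more compounds than are shown below. What is called first, only, known or untested is meant among the compounds shown, and "the series" means these compounds.

Of the compounds shown here, three built on the same core have numbers so far in a functional assay on MGC-803 cells (Homo sapiens) for inhibition, read by MTT assay, with a stated time of 72 h; on this read-out lower numbers stand for stronger inhibition and higher numbers for weaker inhibition. Compound 1 `CCCCCc1ccc(NC(=O)C2CCN(C/C=C/c3ccccc3)CC2)cc1` gives 2550 nM. Compound 2 `COc1ccccc1NC(=O)C1CCN(C/C=C/c2ccccc2)CC1` gives 71200 nM. Compound 3 `O=C(Nc1cccc(F)c1)C1CCN(C/C=C/c2ccccc2)CC1` gives 23300 nM, the second highest of the three numbers, lying under compound 2 and over compound 1.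

Next in the series is compound 4 `N#Cc1ccc(NC(=O)C2CCN(C/C=C/c3ccccc3)CC2)cc1`, not yet measured in this assay. The change from compound 3 is 4-cyanophenyl in place of 3-fluorophenyl on an amide-type nitrogen.

For the measured compounds named here, one measured step bears directly on this change, since it also swaps the group on that nitrogen: a 3.1-fold lower number from compound 2 to compound 3 (0.49 log units; beyond the scatter), a modest step. Going by the values given here, the value of compound 1, 2550 nM, shows that a lower number is reachable with another group at this nitrogen, but no step links it to compound 3. Among the compounds with values here, no measured compound carries a nitrile, so the data set no firm direction. A step no larger than the modest one is expected, and it may stay within the scatter. The expected change is small, a 1.2-fold lower number from compound 3 to compound 4 (0.07 log units; within the scatter). For compound 4 the estimated value is 20000 nM, with an expected range from 7000 nM to 60000 nM.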

Compound 4, half-maximal inhibitory concentration: 28200 nM
Compound 4: the middle estimate sits 1.4-fold (0.15 log units) below what was measured; low and high end bracket the measured number.
By their numbers in this assay, from the lowest: compound 1; then compounds 3 and 4 (each within the scatter of the next); then compound 2.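

In this assay the two groups on the amide-type nitrogen, 3-fluorophenyl and 4-cyanophenyl, cannot be told apart, with a 1.2-fold higher number from compound 3 to compound 4 (0.08 log units; within the scatter) as the step between them. The 4-cyanophenyl group gives a second replacement of 2-methoxyphenyl that shifts the number beyond the scatter, a 2.5-fold lower number from compound 2 to compound 4 (0.40 log units; beyond the scatter), alongside the modest 3.1-fold lower number from compound 2 to compound 3 (0.49 log units; beyond the scatter), so two different groups now stand on the same side of compound 2. The series also gains its first direct step between two groups on the same aromatic carbon, and it is large, an 11-fold higher number from compound 1 to compound 4 (1.04 log units; beyond the scatter), though no measurement at hand accounts for it.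

Still open is whether hexyl, a longer chain, or butyl, a shorter one, on that aromatic carbon would keep a number close to that of compound 1 at 2550 nM, or whether the pentyl chain is a special case among the groups shown. Also open, as far as these compounds go, is whether an amine or a carboxylic acid on that same carbon would separate from compound 4 in this assay, or would stay with it within the scatter.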